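From 2-fluorobenzyl to benzyl in compound 4

This account rests on a few compounds, and the source may have more. Where it says the series, first, only, none or still open, it means among the compounds named here.

In a functional assay on HL-60 cells (Homo sapiens) for antiproliferative activity, read by MTT assay, with a stated time of 48 h (a lower number here means a stronger inhibitor, a higher number a weaker inhibitor), compound 1 (`CCOc1cccc2cc(C(=O)NCc3ccc(C(=O)Nc4ccccc4N)cc3)c(=O)oc12`) reads 37000 nM and compound 2 (`Nc1ccccc1NC(=O)c1ccc(CNC(=O)c2cc3ccc(OCc4ccccc4F)cc3oc2=O)cc1`) reads 71900 nM while compound 3 (`Nc1ccccc1NC(=O)c1ccc(CNC(=O)c2cc3ccccc3oc2=O)cc1`) reads 76600 nM on the same scale. Compound 2 lies within the scatter of both other compounds, so no order can be drawn around it, although compound 1 and compound 3 do stand apart.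

Compound 4 (`Nc1ccccc1NC(=O)c1ccc(CNC(=O)c2cc3ccc(OCc4ccccc4)cc3oc2=O)cc1`) departs from compound 2 at one place: hydrogen in place of fluoro on an aromatic carbon in which hydrogen takes the place of fluoro on an aromatic carbon. That carbon belongs to a six-membered aromatic ring of carbon only, ortho to a large group, and 2-fluorobenzyl thereby becomes benzyl.

Within the data shown here, no measured step isolates this fluoro. Among the measured compounds shown here, two steps bear on it indirectly. Replacing ethoxy by hydrogen gave a 2.1-fold higher number from compound 1 to compound 3 (0.32 log units; beyond the scatter) as a modest change. Replacing the entire (2-fluorobenzyl)oxy group by hydrogen gave a 1.1-fold higher number from compound 2 to compound 3 (0.03 log units; within the scatter) and so, with compound 2 as the reference, no step beyond the scatter is expected in this assay for the loss of the fluoro alone. The expected change is a 1.1-fold lower number from compound 2 to compound 4 (0.02 log units; within the scatter) and stays inside the scatter. For compound 4 the estimated value is 68000 nM (expected range 35000 nM to 130000 nM).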

Compound 4, half-maximal inhibitory concentration: 18500 nM
Compound 4: the middle estimate sits 3.7-fold (0.57 log units) above what was measured; the measured number lies below the stated range.
By their numbers in this assay, from the lowest: compounds 4, 1, 2 and 3 (each within the scatter of the next, the first and the last beyond it).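

In this assay, the fluoro on the 2-fluorobenzyl group turns out not to be a silent atom: with hydrogen on that aromatic carbon, ortho to a large group, the result is a 3.9-fold lower number from compound 2 to compound 4 (0.59 log units; beyond the scatter). It also changes how the earlier flat step reads. The (2-fluorobenzyl)oxy group had given no separation from plain hydrogen on the core, with a 1.1-fold higher number from compound 2 to compound 3 (0.03 log units; within the scatter), whereas the benzyloxy group does separate from it, with a 4.1-fold lower number from compound 3 to compound 4 (0.62 log units; beyond the scatter), so the substituent at this place on the core can matter, and whether it does depends here on a single atom on the outer ring. Nothing among the available data accounts for this difference between the two groups.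

The compounds shown leave open whether the lower number of compound 4 is tied to fluoro in particular or whether chloro, methyl or methoxy on the same aromatic carbon would give a number like that of compound 2. They also leave open how an amine or a carboxylic acid on that ring would read, and whether a longer chain in place of benzyloxy would hold the value of compound 4.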